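Cyclohexanone succinimides: methyl on the saturated ring

The source may report more compounds than this note shows. Statements on the series, on what has been measured and on what is new or still open speak of the compounds shown alone.

Measured in an assay on Sf21 cells for inhibition of cytochrome c oxidase subunit 2 (Homo sapiens), read by spectrophotometry, with a stated time of 5 min; a higher number here means a weaker inhibitor, a lower number a stronger inhibitor:
compound 1 `NS(=O)(=O)c1ccc(N2C(=O)CC(C3CCCCC3=O)C2=O)cc1` gives 21300 nM
compound 2 `O=C1CCCCC1C1CC(=O)N(c2ccccc2)C1=O` gives 45100 nM
compound 3 `O=C1CCCCC1C1CC(=O)N(c2ccc(Br)cc2)C1=O` gives 113000 nM

Compound 2 stands second highest of the three numbers, with a 2.1-fold higher number from compound 1 to compound 2 (0.33 log units; beyond the scatter) on one side and a 2.5-fold higher number from compound 2 to compound 3 (0.40 log units; beyond the scatter) on the other. Compound 4 `CC1CCC(=O)C(C2CC(=O)N(c3ccccc3)C2=O)C1` differs from compound 2 by methyl in place of hydrogen on a saturated ring carbon. Among the compounds with values here, no measured step touches a saturated ring carbon; the three steps seen, a 2.1-fold higher number from compound 1 to compound 2 (0.33 log units; beyond the scatter), a 2.5-fold higher number from compound 2 to compound 3 (0.40 log units; beyond the scatter) and a 5.3-fold higher number from compound 1 to compound 3 (0.72 log units; beyond the scatter), all exchange the group on the aromatic carbon and are modest. Within the data shown here, with no step bearing on this change, a step within the scatter is expected in this assay, in either direction. Compound 4 is therefore estimated at 45000 nM, range 20000 nM to 110000 nM, which means a 1.0-fold lower number from compound 2 to compound 4 (0.00 log units; within the scatter) is expected.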

Compound 4, half-maximal inhibitory concentration: 56500 nM
The estimate for compound 4 lay 1.3-fold (0.10 log units) below the measured number, and the stated range covers the measured number.
By their numbers in this assay, from the lowest: compound 1; then compounds 2, 4 and 3 (each within the scatter of the next, the first and the last beyond it).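

In this assay, a saturated ring carbon now has a measured step of its own: a 1.3-fold higher number from compound 2 to compound 4 (0.10 log units; within the scatter) for methyl in place of hydrogen, two ring bonds from the ring atom that bears a large group. Unlike the three exchanges on the aromatic carbon, all beyond the scatter, this change stays within it. No measurement shown gives a reason for this result.

Open, going by these compounds, is whether an ethyl, a hydroxyl or an amine at this ring carbon would also stay within the scatter. Also open, on these data alone, is whether methyl would do the same on the core of compound 1.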